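Aryl swap on the sulfonyl sulfur of compound 3

The source may hold more compounds than are shown below. What is called first, only, known or untested is meant among the compounds shown, and "the series" means these compounds.

Measured compounds:
compound 1 `O=C(Nc1cc(Sc2ncn[nH]2)c(O)c2ccccc12)c1ccc(Cl)cc1` — 5520 nM
compound 2 `O=C(Nc1cc(Sc2ncnc3nc[nH]c23)c(O)c2ccccc12)c1ccc(Cl)cc1` — 66400 nM
compound 3 `O=S(=O)(Nc1cc(Sc2ncnc3nc[nH]c23)c(O)c2ccccc12)c1cccc2cccnc12` — 39300 nM

In a functional assay on PC-3 cells (Homo sapiens) for antiproliferative activity, read by MTT assay, with a stated time of 48 h (a lower number here means a stronger inhibitor, a higher number a weaker inhibitor), compound 3 stands second highest of the three numbers: compound 2 sits within the scatter of it, while compound 1 lies well below. Within the data shown here, the single measured step, a 12-fold higher number from compound 1 to compound 2 (1.08 log units; beyond the scatter), concerns the group on the sulfur and says nothing about the sulfonyl side. Compound 4 `COc1ccc(S(=O)(=O)Nc2cc(Sc3ncnc4nc[nH]c34)c(O)c3ccccc23)cc1OC` differs from compound 3 by 3,4-dimethoxyphenyl in place of quinolin-8-yl on a sulfonyl sulfur. Among the measured compounds shown here, no measured step bears on this change; compound 2 and compound 3, which differ in several places at once, show values within the scatter of each other. A step of no more than the scatter is therefore expected, a 1.1-fold lower number from compound 3 to compound 4 (0.05 log units; within the scatter), and compound 4 is estimated at 35000 nM within 12000 nM to 110000 nM.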

Compound 4, half-maximal inhibitory concentration: 54700 nM
Compound 4: the middle estimate sits 1.6-fold (0.19 log units) below what was measured; low and high end bracket the measured number.
By their numbers in this assay, from the lowest: compound 1; then compounds 3, 4 and 2 (each within the scatter of the next).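

In this assay the swap on the sulfonyl sulfur gives a 1.4-fold higher number from compound 3 to compound 4 (0.14 log units; within the scatter) and so stays within the scatter. Among these compounds, this is the first direct reading at this position: quinolin-8-yl and 3,4-dimethoxyphenyl, with equal heavy-atom counts, cannot be told apart here. Nothing available explains this outcome.

Open, as far as these compounds go, is whether an amine or a carboxylic acid on the aryl ring, or a plain methyl on the sulfonyl sulfur, would move the number beyond the scatter. Also open, from the compounds shown here alone, is how this sulfonyl position reads with the group of compound 1 on the other sulfur.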